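Replacing the 3-cyanophenyl group of compound 3

The compounds below may be only part of what the source reports. "The series", "measured", "known", "first", "only" and "open" are said of these compounds alone.

Results in a toxicity assay on HeLa cells (Homo sapiens) for cytotoxicity, read by colorimetric assay, with a stated time of 72 h (a higher number here means that more compound is tolerated, a lower number that less compound is tolerated), so far
- compound 1 `O=c1nc(N2CC[C@@](O)(COc3ccc(F)cc3)[C@H](O)C2)sc2c([N+](=O)[O-])cc(C(F)(F)F)cc12` gives 18400 nM as a measured number
- compound 2 `COc1cc2c(cc1OC)[C@@H](C[C@@H](O)c1ccccc1)N(c1nc(=O)c3cc(C(F)(F)F)cc([N+](=O)[O-])c3s1)CC2` gives > 85000 nM as a limit of the assay
- compound 3 `N#Cc1cccc(N2CCN(c3nc(=O)c4cc(C(F)(F)F)cc([N+](=O)[O-])c4s3)CC2)c1` gives > 108000 nM as a limit of the assay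

Compound 3 has no exact number, only > 108000 nM as a limit of the assay. Compound 1 is the only one of the three with a measured number.

Compound 4 `O=C(CN1CCN(c2nc(=O)c3cc(C(F)(F)F)cc([N+](=O)[O-])c3s2)CC1)Nc1ccccn1` keeps the shared core and the six-membered ring with two nitrogens. It carries ((pyridin-2-yl)carbamoyl)methyl in place of 3-cyanophenyl on an amine nitrogen in a ring and so differs from compound 3 in this one place.

For the measured compounds named here, no two measured compounds differ in only one place, so the size of such a change has not been seen directly. Compound 1 at 18400 nM shows that this core can give a measurable number, so a modest move toward less compound tolerated is expected. The estimated change is an at least 1.8-fold lower number from compound 3 to compound 4 (0.25 log units; that floor lies within the scatter) in this assay and may again appear only as a limit. For compound 4 the expected value is 60000 nM with an estimated range from 18000 nM to 100000 nM in this assay as the working guess.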

Compound 4, half-maximal cytotoxic concentration: 44500 nM
Compound 4: middle estimate off by 1.3-fold (0.13 log units), on the high side; the measured number falls inside the stated range.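

In this assay, for the compounds shown here, the change gives the one direct reading of a single swap on this amine nitrogen in the six-membered ring: ((pyridin-2-yl)carbamoyl)methyl in place of 3-cyanophenyl gives an at least 2.4-fold lower number from compound 3 to compound 4 (0.38 log units; beyond the scatter). The group on this nitrogen can therefore shift how much compound is tolerated, by more than the usual scatter. Compound 3 has only a limit of the assay, so this step is a floor and its full size remains unknown: the limit of > 108000 nM in this assay, at which 1 of the 4 values shown sits.

The compounds shown do not separate the roles of the pyridine ring, the amide and the methyl link within the new group. They also leave open how a plain phenyl amide, a carboxylic acid or a longer chain ending in an amine on this nitrogen would compare.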